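Chloroaryl Chalcone Series: BGC-823 Cytotoxicity Notes

The source may report more compounds than this note shows. Statements on the series, on what has been measured and on what is new or still open speak of the compounds shown alone.

Compound 1 `Cc1nc(Nc2cccc(Cl)c2)sc1C(=O)/C=C/c1ccc(Cl)cc1` is the anchor of the series. In a functional assay on BGC-823 cells (Homo sapiens) for cytotoxicity, read by MTT assay (on this read-out higher numbers stand for weaker inhibition and lower numbers for stronger inhibition), compound 1 gives > 25000 nM, which is a limit of the assay rather than a number. Compound 2 `COc1cc(/C=C/C(=O)c2sc(Nc3ccc(C)cc3)nc2C)cc(OC)c1OC` gives > 25000 nM in this assay, again a limit. Compound 3 `Cc1ccccc1Nc1nc(C)c(C(=O)/C=C/c2ccccc2Cl)s1` likewise gives > 25000 nM in this assay, also a limit. No measured number therefore exists in the series; the limit of > 25000 nM in this assay, at which 3 of the 3 values shown sit, is where all three values sit, no step between measured compounds can be counted, and on the numbers shown nothing separates compound 1 from compound 2 or compound 3.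

Compound 4 `Cc1nc(Nc2ccc(Cl)c(Cl)c2)sc1C(=O)/C=C/c1ccc(Cl)cc1` differs from compound 1 by chloro in place of hydrogen on an aromatic carbon; cut one bond further out, the change reads 3-chlorophenyl to 3,4-dichlorophenyl. With every shown value sitting at the limit, the step to compound 4 has no measured counterpart to lean on. The expected step is a number no higher from compound 1 to compound 4 (the limit leaves the size open), that is, none beyond the scatter, since compound 1 itself only reaches the limit > 25000 nM. Compound 4 is expected to give about 25000 nM in this assay, with a range from 10000 nM to 60000 nM, and the most likely outcome is that this assay again reports only a limit.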

Compound 4, half-maximal inhibitory concentration: 22700 nM
The estimate for compound 4 lay 1.1-fold (0.04 log units) above the measured number, and the stated range covers the measured number.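

Compound 4 is the only compound shown that carries a measured number in this assay rather than a limit: the limit of > 25000 nM in this assay, at which 3 of the 4 values shown sit.

Chloro in place of hydrogen at this position, ortho to a chloro group and para to a large group, gives an at least 1.1-fold lower number from compound 1 to compound 4 (0.04 log units; that floor lies within the scatter). Among the compounds shown here, compound 1 holds only a limit, so that floor is all that can be read, and the true size of the step stays open; what the change adds to the earlier compounds is a first readable number for 3,4-dichlorophenyl, not a demonstrated gain beyond the scatter.

The compounds shown leave open whether chloro itself matters at this position, since no other group stands there for comparison; a bromo group, a nitrile or an amine in the same place on the 3-chlorophenyl group would test this. For the compounds shown here, it also remains open whether the same change would act alike in the settings of compound 2 and compound 3, which differ from compound 1 in more than one place and so give no step to read.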